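The source may report more compounds than this note shows. Statements on the series, on what has been measured and on what is new or still open speak of the compounds shown alone.

Measured in a functional assay on HL-60 cells (Homo sapiens) for inhibition, read by MTT assay, with a stated time of 72 h; a higher number here means a weaker inhibitor, a lower number a stronger inhibitor:
- compound 1 `Cc1nc(-c2ccccc2F)c(C(=O)N2CCN(c3cc(Cl)cc(Cl)c3)CC2)s1`: 157 nM
- compound 2 `Cc1nc(-c2ccccc2Cl)c(C(=O)N2CCN(c3cccc(Cl)c3)CC2)o1`: 132 nM
- compound 3 `Cc1ccc(C)c(N2CCN(C(=O)c3oc(C)nc3-c3ccccc3Cl)CC2)c1`: > 1000 nM

Compound 3 gives no number, only a limit of > 1000 nM. Compound 4 `Cc1ccc(C)c(N2CCN(C(=O)c3oc(C)nc3-c3ccc(Cl)cc3)CC2)c1` has 4-chlorophenyl in place of 2-chlorophenyl on an aromatic carbon. Going by the values given here, no measured step touches this place. Among the compounds with values here, the one nearby evidence is an at least 7.5-fold higher number from compound 2 to compound 3 (0.87 log units; beyond the scatter), a change on an amine nitrogen in a ring, and compound 4 keeps the 2,5-dimethylphenyl of that step. It gives no size for the new change, so no shift beyond the scatter is expected in this assay. The expected step is a step that the limit leaves unreadable from compound 3 to compound 4. For compound 4 the estimate is 1500 nM, with an expected range of 500 nM to 5000 nM.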

Compound 4, half-maximal inhibitory concentration: "not active" (no number reported)
No number was reported for compound 4; there is nothing to compare the estimate with.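

Compound 3 gives only a limit, > 1000 nM. Compound 4 is reported as not active, without a number, so no step can be read between these two compounds. The compounds shown leave open whether 4-chlorophenyl in place of 2-chlorophenyl changes the inhibition at all.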